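The source may hold more compounds than are shown below. What is called first, only, known or untested is meant among the compounds shown, and "the series" means these compounds.

In a physicochemical assay for metabolic stability, read by LC-MS, in phosphate buffer, with a stated time of 3 h, at pH 7.4, tested at 50 uM (on this read-out lower numbers stand for a less stable compound and higher numbers for a more stable compound), compound 1, `COC(=O)C1=C(S[C@@H]2CN[C@H](C(=O)Nc3cccc(C(=O)OC)c3)C2)[C@H](C)[C@@H]2[C@@H]([C@@H](C)O)C(=O)N12`, is reported only as a limit of the assay, > 95%. Compound 2, `C[C@@H](O)[C@H]1C(=O)N2C(C(=O)OCOC(=O)C(C)(C)C)=C(S[C@@H]3CN[C@H](C(=O)Nc4cccc(C(=O)OCOC(=O)C(C)(C)C)c4)C3)[C@H](C)[C@H]12`, is likewise reported as a limit, > 95%. Compound 3, `C[C@@H](O)[C@H]1C(=O)N2C(C(=O)OCOC(=O)OC(C)(C)C)=C(S[C@@H]3CN[C@H](C(=O)Nc4cccc(C(=O)O)c4)C3)[C@H](C)[C@H]12`, is also given as a limit rather than a number, > 95%. Where compound 3 stands among the measured compounds can thus be stated only in one way: all three sit at the limit of > 95% in this assay, at which 3 of the 3 values shown sit, so no value among them is an actual number and nothing separates one from another. For the measured compounds named here, no step between two measured compounds that differ in a single place is available in this set, and so no measured change in this assay can be pointed to.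

Compound 4, `C[C@@H](O)[C@H]1C(=O)N2C(C(=O)OCOC(=O)C3CCCCC3)=C(S[C@@H]3CN[C@H](C(=O)Nc4cccc(C(=O)O)c4)C3)[C@H](C)[C@H]12`, has not yet been measured in this assay. It differs from compound 3 in one place:

cyclohexyl in place of tert-butoxy on a carbonyl carbon

With every measured compound sitting at the limit, the expectation for compound 4 rests on that alone. The expected step in this assay is a step that the limit leaves unreadable from compound 3 to compound 4, which is to say none beyond the scatter. Compound 4 is accordingly expected to give about 97%, within a range from 88% to 100%, and most probably again as a limit.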

Compound 4, percent of the compound remaining: > 95%
Compound 4: only a limit was reported (the forecaster's own chance of this, stated with the estimate: 85%); the middle value lies beyond the limit too.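

No step from compound 3 to compound 4 can be read in this assay, since both compounds are reported only as limits: the limit of > 95% in this assay, at which 4 of the 4 values shown sit.

The compounds shown leave open whether cyclohexyl in place of tert-butoxy on a carbonyl carbon changes the percent of compound remaining at all, and what actual number any of the four would give.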